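Swapping hydroxyamino for hydroxy on a carbonyl carbon

This account rests on a few compounds, and the source may have more. Where it says the series, first, only, none or still open, it means among the compounds named here.

In a functional assay on NCI-H1975 cells (Homo sapiens) for inhibition, with a stated time of 72 h (on this read-out higher numbers stand for weaker inhibition of growth and lower numbers for stronger inhibition of growth), compound 1 `COC(=O)c1ccc(CN(C)C(=O)c2cc(C(C)C)c(O)cc2O)cc1` gives 3500 nM, while compound 2 `CC(C)c1cc(C(=O)N(C)Cc2ccc(C(=O)NO)cc2)c(O)cc1O` gives 1700 nM, the lower of the two numbers. Going by the values given here, the only measured step, a 2.1-fold lower number from compound 1 to compound 2 (0.31 log units; beyond the scatter), is modest and came with hydroxyamino in place of methoxy on a carbonyl carbon. Compound 3 `CC(C)c1cc(C(=O)N(C)Cc2ccc(C(=O)O)cc2)c(O)cc1O` has hydroxy in place of hydroxyamino on a carbonyl carbon. Among the compounds with values here, no measured step covers this exact swap, so the modest size of a 2.1-fold lower number from compound 1 to compound 2 (0.31 log units; beyond the scatter) is the only guide, and a similarly modest upward move in this assay is expected. The expected step is a 2.9-fold higher number from compound 2 to compound 3 (0.47 log units; beyond the scatter). For compound 3 the estimated value is 5000 nM, with an expected range of 2000 nM to 15000 nM.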

Compound 3, concentration for 50% growth inhibition: 30000 nM
For compound 3 the middle estimate is 6.0-fold (0.78 log units) below the measured one; the measured number lies above the stated range.
By their numbers in this assay, from the lowest: compound 2; then compound 1; then compound 3.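

At this carbonyl carbon, the choice of group can matter far more than the earlier pair suggested: in this assay, hydroxy in place of hydroxyamino brings an 18-fold higher number from compound 2 to compound 3 (1.25 log units; beyond the scatter). Hydroxy also falls behind methoxy at the same carbon, with an 8.6-fold higher number from compound 1 to compound 3 (0.93 log units; beyond the scatter). Thus, of these three compounds, the one carrying carboxy inhibits growth most weakly, and no available measurement explains why.

Still open, going by these compounds, is whether an amino or a methylamino group on this carbonyl carbon would behave more like hydroxyamino or more like hydroxy.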